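A few compounds are considered here, and "the series" means these few. Any claim that something is new, unique, unknown or untested is made for them only; others in the source may bear on it.

Measured compounds in a functional assay on HeLa cells (Homo sapiens) for inhibition, read by MTT assay, with a stated time of 72 h; a lower number here means a stronger inhibitor, a higher number a weaker inhibitor:
compound 1 `CN(C(=O)NC(=O)c1cccc(C(F)(F)F)c1)c1nc(C(F)(F)F)c(C(=O)N/N=C/c2cc(C(F)(F)F)cc(C(F)(F)F)c2)s1` gives 5.34 ug/mL
compound 2 `CN(C(=O)NC(=O)c1ccc(C(F)(F)F)cc1)c1nc(C(F)(F)F)c(C(=O)N/N=C/c2cccc(C(F)(F)F)c2)s1` gives 6.2 ug/mL
compound 3 `CN(C(=O)NC(=O)c1c(Cl)cccc1Cl)c1nc(C(F)(F)F)c(C(=O)N/N=C/c2ccccc2C(F)(F)F)s1` gives 5.23 ug/mL

Among the measured compounds shown here, the three measured members sit close together in this assay. Compound 3 has the lowest of the three numbers, but its nearest neighbour, compound 1, lies within the scatter, as does compound 2; no ordering among the three can be claimed, and compound 3 cannot be called the most potent.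

Compound 4 `CN(C(=O)NC(=O)c1c(F)cccc1F)c1nc(C(F)(F)F)c(C(=O)N/N=C/c2ccccc2C(F)(F)F)s1` is the next member. It differs from compound 3 in one place: 2,6-difluorophenyl in place of 2,6-dichlorophenyl on a carbonyl carbon. The rest of the shared core, including the hydrazone-bearing arm, is unchanged between compound 3 and compound 4.

For the measured compounds named here, no measured pair shows a step of this kind, so the expectation rests only on the spread of the three values. Across compounds 1, 2 and 3, changes in the aryl substitution pattern on the acyl arm leave this assay essentially unmoved. The step from compound 3 to compound 4 is therefore expected to be small, if anything a slight rise, and likely to stay within the scatter: a 1.2-fold higher number from compound 3 to compound 4 (0.07 log units; within the scatter).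

For compound 4 the estimated value in this assay is 6.2 ug/mL, with a range from 3 ug/mL to 13 ug/mL.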

Compound 4, half-maximal inhibitory concentration: 19.6 ug/mL
Estimate against measurement, compound 4: 3.2-fold (0.50 log units) below; measured number outside the range, above it.
By their numbers in this assay, from the lowest: compounds 3, 1 and 2 (each within the scatter of the next); then compound 4.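

In this assay, among the compounds shown here, the aryl group on the carbonyl carbon is not a silent position: with the rest of the shared core unchanged, 2,6-difluorophenyl in place of 2,6-dichlorophenyl gives a 3.7-fold higher number from compound 3 to compound 4 (0.57 log units; beyond the scatter), the only one-place step so far and one that lies beyond the scatter. Compounds 1, 2 and 3 differ from one another in more than one place, so their closeness could not show what this position does when changed alone; here the step appears even though the two groups match in heavy-atom count, ring type and counted hydrogen-bond donors and acceptors, and differ only in chlorine versus fluorine. No measurement on the two groups accompanies this step, so the rise remains without an assigned cause.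

From the compounds shown here alone, whether the values follow the halogen in a graded way remains open, as a phenyl group without substituents or a 2,6-dimethylphenyl group at the same carbonyl carbon would be needed to place the two halogen-bearing groups on a wider scale. Also open, going by these compounds, is whether the same exchange gives a step of similar size when the hydrazone-bearing arm carries a different aryl group.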